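Turning one stereocentre: from compound 2 to compound 3

The compounds below may be only part of what the source reports. "The series", "measured", "known", "first", "only" and "open" are said of these compounds alone.

Values measured so far in a functional assay on the whole organism with Mus musculus as the target, in the maximal electroshock model, with a stated time of 0.5 h (a lower number here means that less compound is needed, a higher number that more compound is needed for the effect), are these

Compound 1 `CC[C@]1(c2ccccc2)OC(=O)NC1=O` gives 91 mg/kg
Compound 2 `O=C1O[C@]2(c3ccccc3)CCCCCN1C2=O` gives 82 mg/kg

Compound 2 stands at 82 mg/kg and compound 1 at 91 mg/kg in the same test, so the two lie within the usual scatter of each other and neither can be set ahead. Compound 3 `O=C1O[C@@]2(c3ccccc3)CCCCCN1C2=O` has yet to be measured. Its relation to compound 2 is simple to state: the two compounds have the same atoms and bonds and differ only in configuration as drawn: 1 of 1 stereo elements differ; a stereocentre at a saturated ring carbon is drawn S in compound 2 and R in compound 3 and nothing else separates them. Going by the values given here, no pair differing only in configuration has been measured, so the data give no direct guide to the size of this step. A change beyond the scatter cannot be ruled out, yet none is expected, with only a slight lean towards a higher number in this assay here. The expected step is a 1.3-fold higher number from compound 2 to compound 3 (0.13 log units; within the scatter) as estimated. For compound 3 the estimate is 110 mg/kg with an expected range from 45 mg/kg to 270 mg/kg in this reading.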

Compound 3, dose for half-maximal effect: 45 mg/kg
Estimate against measurement, compound 3: 2.4-fold (0.39 log units) above; measured number inside the range.
By their numbers in this assay, from the lowest: compounds 3, 2 and 1 (each within the scatter of the next, the first and the last beyond it).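

This pair is the first in the set to test the stereocentre on its own, and the comparison is direct: the fact that compounds 2 and 3 differ only in the configuration as drawn

In this assay, changing the saturated ring carbon from S to R gives a 1.8-fold lower number from compound 2 to compound 3 (0.26 log units; within the scatter), so neither configuration can be set ahead of the other. The pair therefore gives no sign that the configuration at this position decides the result in this test, although a step of this size does not exclude a real preference.

The compounds shown leave open whether the same holds once a chlorine or a methoxy group is carried on the shared core. They also leave open whether the configuration would count for more with an amine or a carboxylic acid in the structure.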